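A few compounds are considered here, and "the series" means these few. Any claim that something is new, unique, unknown or untested is made for them only; others in the source may bear on it.

Measured compounds in a functional assay on HCT-15 cells (Homo sapiens) for inhibition, read by sulforhodamine B assay, with a stated time of 48 h; a lower number here means that less compound is tolerated, a higher number that more compound is tolerated:
Compound 1 `COc1ccc(-c2cc(/C=C/C(=O)c3ccc(N)cc3)[nH]n2)cc1` gives 34900 nM.
Compound 2 `COc1cc(-c2cc(/C=C/C(=O)c3ccc(N)cc3)[nH]n2)cc(OC)c1OC` gives only the limit > 100000 nM.
Compound 3 `COc1ccc(C(=O)/C=C/c2cc(-c3cc(OC)c(OC)c(OC)c3)n[nH]2)cc1` gives only the limit > 100000 nM.

Compound 2 thus stands at the limit of this assay, as does compound 3 (the limit of > 100000 nM in this assay, at which 2 of the 3 values shown sit); the step that the two limits leave unreadable from compound 2 to compound 3 cannot be read. Compound 1 alone gives a number. Compound 4 `COc1ccc(-c2cc(/C=C/C(=O)c3ccc(N)cc3)[nH]n2)cc1OC` differs from compound 2 by hydrogen in place of methoxy on an aromatic carbon. Within the data shown here, no measured step covers this change directly, and the step from compound 2 to compound 3 gives no size, so only the values of compound 1 and compound 2 frame it. Compound 4 is expected to lie between them, with an expected step of an at least 1.5-fold lower number from compound 2 to compound 4 (0.18 log units; that floor lies within the scatter) that may itself not be resolvable as a number. The estimate for compound 4 is 65000 nM, range 25000 nM to 160000 nM.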

Compound 4, concentration lethal to 50% of the cells: 33000 nM
Estimate against measurement, compound 4: 2.0-fold (0.29 log units) above, and the stated range covers the measured number.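

In this assay, hydrogen in place of methoxy at this position, ortho to a methoxy group, has a readable effect: an at least 3.0-fold lower number from compound 2 to compound 4 (0.48 log units; beyond the scatter). The other side of the pair shows no such effect, with a 1.1-fold lower number from compound 1 to compound 4 (0.02 log units; within the scatter), so one methoxy added to the core of compound 1 does not separate the two compounds. The readable number gives way to a limit only in compound 2, which carries one methoxy more than compound 4: the limit of > 100000 nM in this assay, at which 2 of the 4 values shown sit.

From the compounds shown here alone, the full size of the step from the limit remains open. Also open, going by these compounds, is whether a hydroxyl or a fluorine on this carbon would behave like hydrogen or like methoxy.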